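Swapping a biaryl substituent for a branched alkyl chain

A few compounds are considered here, and "the series" means these few. Any claim that something is new, unique, unknown or untested is made for them only; others in the source may bear on it.

Of the compounds shown here, three built on a shared core have been measured in an ADME assay for permeability, using PAMPA, with a stated time of 30 min, at pH 7.4; on this read-out lower numbers stand for lower permeability and higher numbers for higher permeability. Compound 1 `COc1ccc(-c2ccc3c(NCCCNCc4cccc(OC)c4O)ccnc3c2)cc1` gives 237 10^-6 cm/s in this assay. Compound 2 `COc1ccc(-c2ccc3c(NCCCNCc4ccco4)ccnc3c2)cc1` gives 237 10^-6 cm/s, and compound 3 `Clc1ccc(Oc2ccc3c(NCCCNCc4ccco4)ccnc3c2)cc1` gives 317 10^-6 cm/s. Compound 1 and compound 2 stand level at the digits shown, together the lowest of the three numbers, and the step of no change at the digits printed from compound 1 to compound 2 (within the scatter) lies within the scatter. The step of a 1.3-fold higher number from compound 2 to compound 3 (0.13 log units; within the scatter) also stays within the scatter, so the three measured numbers cannot be told apart.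

Compound 4 `CCC(CC)c1ccc2c(NCCCNCc3cccc(OC)c3O)ccnc2c1` has not yet been measured. It differs from compound 1 in one place: pentan-3-yl in place of 4-methoxyphenyl on an aromatic carbon. Among the measured compounds shown here, no measured step exchanges a biaryl substituent for a branched chain at that position. For the measured compounds named here, the closest precedent is the step from compound 2 to compound 3, which changes the same aromatic carbon and moved the number by a 1.3-fold higher number from compound 2 to compound 3 (0.13 log units; within the scatter), within the scatter. On that footing the author expects compound 4 to remain in the same region as compound 1, with a step of a 1.1-fold higher number from compound 1 to compound 4 (0.02 log units; within the scatter) that is expected to stay within the scatter. The estimate for compound 4 in this assay is 250 10^-6 cm/s, expected to fall between 150 10^-6 cm/s and 400 10^-6 cm/s.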

Compound 4, apparent permeability: 23 10^-6 cm/s
The estimate for compound 4 lay 11-fold (1.04 log units) above the measured number, and the stated range ends above it.
By their numbers in this assay, from the lowest: compound 4; then compounds 1, 2 and 3 (each within the scatter of the next).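

In this assay, among the compounds shown here, this aromatic carbon proved far from indifferent to what it carries: pentan-3-yl in place of 4-methoxyphenyl gave a 10-fold lower number from compound 1 to compound 4 (1.01 log units; beyond the scatter), while the only earlier change at the same carbon gave a 1.3-fold higher number from compound 2 to compound 3 (0.13 log units; within the scatter). For the compounds shown here, the flat picture from the earlier compounds therefore does not hold for every group at this position, and this is the first step here to lie beyond the scatter; both groups in the earlier step carry a six-membered aromatic ring of carbon only, whereas pentan-3-yl has no ring and the exchange also takes away the hydrogen-bond acceptor counted in 4-methoxyphenyl. Nothing measured on these compounds explains why the number dropped.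

The compounds shown do not separate the loss of the ring from the loss of the acceptor or from the branched shape of the chain, and a plain phenyl, a cyclohexyl ring or an unbranched pentyl chain on the same carbon would pull these apart. They also leave open whether pentan-3-yl gives a similar drop when the furan-2-yl side chain of compound 2 stands in place of the 2-hydroxy-3-methoxyphenyl one.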